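The source may report more compounds than this note shows. Statements on the series, on what has been measured and on what is new or still open speak of the compounds shown alone.

Measured compounds:
Compound 1, `CCCCOc1ccc(C(CC)NC(=O)Oc2ccc(F)cc2)cc1`, with 12 nM in an assay on H4 cells for inhibition of Fatty-acid amide hydrolase 1 (Homo sapiens); on this read-out lower numbers stand for stronger inhibition and higher numbers for weaker inhibition.
Compound 2, `CCCCOc1ccc(C(CC)NC(=O)Oc2ccccc2)cc1`, with 12 nM in this assay.
Compound 3, `CCCCCCOc1ccc(NC(=O)Oc2ccccc2)cc1`, with 31 nM in this assay.

Compound 1 and compound 2 share one core and differ in a single spot: fluoro in place of hydrogen on an aromatic carbon. This change gave no change at the digits printed from compound 2 to compound 1 (within the scatter), so the fluorine at that spot left the read-out where it was.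

Compound 3 is built on a different core; how its core differs from that of compound 2 is not broken down here. Of the three measured compounds, compound 3 gives the highest number, beyond the scatter from both compound 1 and compound 2.

The unmeasured compound 4, `CCCCCCOc1ccc(NC(=O)Oc2ccccc2F)cc1`, arises from compound 3 by fluoro in place of hydrogen on an aromatic carbon. Among the compounds with values here, this is the same kind of change as the one from compound 2 to compound 1, but not the same: there the fluorine sits para to a large group, here it sits ortho to a large group, and the surrounding core is different. Within the data shown here, the only guide is that the earlier change produced no change at the digits printed from compound 2 to compound 1 (within the scatter) in this assay. On that basis the step from compound 3 to compound 4 is expected to be small, a 1.2-fold lower number from compound 3 to compound 4 (0.09 log units; within the scatter), with room on either side given the changed place. Compound 4 is therefore estimated at 25 nM, expected between 8 nM and 80 nM.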

Compound 4, half-maximal inhibitory concentration: 710 nM
For compound 4 the middle estimate is 28-fold (1.45 log units) below the measured one; measured number outside the range, above it.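

In this assay, putting fluoro in place of hydrogen on the phenoxy ring of compound 3 weakens inhibition sharply, with a 23-fold higher number from compound 3 to compound 4 (1.36 log units; beyond the scatter). The result of this change on one core therefore did not predict its result on the other, as the two steps show when set side by side: the same change on two cores in this assay, no change at the digits printed (within the scatter) from compound 2 to compound 1 and a 23-fold higher number (1.36 log units; beyond the scatter) from compound 3 to compound 4, 23-fold (1.36 log units) apart, beyond the scatter of two such steps. This does not show that the core alone decides the outcome, since the fluorine in compound 4 sits ortho to a large group while the fluorine in compound 1 sits at another place on its ring, so core and place change together between the two steps, and these two pairs cannot tell their contributions apart.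

The compounds shown leave open what a 2-fluorophenoxy group would do on the core of compound 2, and what fluoro at the position it holds in compound 1 would do on the core of compound 3; either pairing would help separate the role of the core from that of the place. They also leave open whether a chloro or methyl group ortho to a large group would give a step like the one seen with fluoro.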